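The source may hold more compounds than are shown below. What is called first, only, known or untested is meant among the compounds shown, and "the series" means these compounds.

In an assay on isolated protein for inhibition of alpha-ketoglutarate-dependent dioxygenase alkB homolog 3 (Homo sapiens), read by fluorescence, with stated times of 60 min and 15 min (on this read-out higher numbers stand for weaker inhibition and lower numbers for stronger inhibition), compound 1 `Cc1ccc2c(c1)C(c1ccccc1)=C(Br)C2=O` gives only a limit, > 50000 nM. Compound 2 `Cc1ccc(C2=C(Br)C(=O)c3ccc(C)cc32)cc1` likewise gives only a limit in this assay, > 50000 nM. The change from compound 1 to compound 2 is methyl in place of hydrogen on an aromatic carbon, and its size is a step that the two limits leave unreadable from compound 1 to compound 2, because of the limit of > 50000 nM in this assay, at which 3 of the 3 values shown sit. Compound 3 `COc1ccc(C2=C(Cl)C(=O)c3ccc(-c4ccccc4)cc32)cc1` also gives only a limit in this assay, > 50000 nM. The difference between the core of compound 1 and the core of compound 3 is not broken down here. Compound 4 `COc1ccc(C2=C(Cl)C(=O)c3ccc(-c4ccc(C)cc4)cc32)cc1` has not yet been measured in this assay; it differs from compound 3 by methyl in place of hydrogen on an aromatic carbon, the same change as that from compound 1 to compound 2. The step from compound 3 to compound 4 is expected to be a step that the limit leaves unreadable from compound 3 to compound 4, resting on the unreadable step that the two limits leave unreadable from compound 1 to compound 2. Compound 4 is expected to give about 80000 nM, within a range from 30000 nM to 300000 nM, most probably reported only as a limit once more.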

Compound 4, half-maximal inhibitory concentration: 9800 nM
Estimate against measurement, compound 4: 8.2-fold (0.91 log units) above, outside the stated range (below it).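

In this assay, methyl in place of hydrogen on an aromatic carbon, here phenyl to 4-methylphenyl, gives an at least 5.1-fold lower number from compound 3 to compound 4 (0.70 log units; beyond the scatter), so on the core of compound 3 the change brings a gain beyond the scatter. The same change on the core of compound 1 cannot be read, because compound 1 and compound 2 both stay at a limit: the limit of > 50000 nM in this assay, at which 3 of the 4 values shown sit. The pair of compound 3 and compound 4 therefore does not show that the change carries from one core to the other, only that it does not fail on the core of compound 3.

The compounds shown leave open how far the number falls, since compound 3 gives only a limit. They also leave open whether an ethyl, an amine or a carboxylic acid in place of that methyl would lower the number further.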